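The source may hold more compounds than are shown below. What is called first, only, known or untested is meant among the compounds shown, and "the series" means these compounds.

Working notes on the series.

Compound 1 `COC(=O)CC/C(C)=C/Cc1c(OC)c(C)c2c(c1OCC#CCN1CCN(c3ccc(C)cc3)CC1)C(=O)OC2` is one of three analogues measured so far in a functional assay on MDA-MB-231 cells (Homo sapiens) for inhibition, read by sulforhodamine B assay; a higher number here means a weaker inhibitor, a lower number a stronger inhibitor. In this assay compound 1 gives only a limit of the assay, > 50000 nM, and no number. Compound 2 `COC(=O)CC/C(C)=C/Cc1c(OC)c(C)c2c(c1OCC#CCN1CCC(Cc3ccccc3)CC1)C(=O)OC2` likewise gives only a limit, > 50000 nM, in this assay. For the measured compounds named here, compound 3 `CCCCNc1ccc(CC#CCOc2c(C/C=C(\C)CCC(=O)OC)c(OC)c(C)c3c2C(=O)OC3)cc1` is the only member of the set with a numeric value, 19800 nM in this assay. Compound 1 therefore stands at the limit of > 50000 nM in this assay, at which 2 of the 3 values shown sit, and no ranked position among the three can be read from it.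

Going by the values given here, no pair of measured compounds differs in one place, so no measured step is available. Compound 4 `COC(=O)CC/C(C)=C/Cc1c(OC)c(C)c2c(c1OCC#CCN1CCN(Cc3ccc(Cl)cc3)CC1)C(=O)OC2` differs from compound 1 by 4-chlorobenzyl in place of 4-methylphenyl on an amine nitrogen in a ring. Compound 2 carries a benzyl group on its ring amine and also sits at the limit, which gives no ground for expecting a step beyond the scatter. The step from compound 1 to compound 4 is expected to be an at least 1.1-fold lower number from compound 1 to compound 4 (0.04 log units; that floor lies within the scatter), within the scatter. Compound 4 is estimated at 45000 nM, between 12000 nM and 200000 nM.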

Compound 4, half-maximal inhibitory concentration: > 50000 nM
Compound 4: only a limit was reported; the forecaster's own chance of this, stated with the estimate: 55%; middle value at least 1.1-fold (0.04 log units) away from the limit.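

Compound 1 and compound 4 both give only a limit in this assay, so no step can be read between them: the limit of > 50000 nM in this assay, at which 3 of the 4 values shown sit.

On these data alone, whether 4-chlorobenzyl in place of 4-methylphenyl on an amine nitrogen in a ring shifts the inhibition at all remains open.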